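A few compounds are considered here, and "the series" means these few. Any claim that something is new, unique, unknown or untested is made for them only; others in the source may bear on it.

Working notes on the series. Among the measured compounds shown here, compound 1 `Nc1c(C(=O)NC2CCCC2)oc2nc(-c3ccccc3)cc(C(F)(F)F)c12` and compound 2 `CCNC(=O)c1oc2nc(-c3cccs3)cc(C(F)(F)F)c2c1N` are the two compounds measured so far. In a functional assay on HepG2 cells (Homo sapiens) for antiproliferative activity, read by MTT assay (a lower number here means a stronger inhibitor, a higher number a weaker inhibitor), compound 1 gives 32400 nM, and in this assay compound 2 gives 12100 nM. Compound 2 thus has the lower of the two numbers, with compound 1 sitting at a higher number beyond the usual scatter; the two structures differ in more than one place, so no single step can be read from that pair.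

Compound 3 `Nc1c(C(=O)NC2CCCC2)oc2nc(-c3cccs3)cc(C(F)(F)F)c12` is not yet measured. It differs from compound 2 by cyclopentyl in place of ethyl on an amide-type nitrogen. The same amide substituent is also present in compound 1, but the data give no isolated reading of this change. A small step is expected, in this assay perhaps toward a somewhat higher number, though possibly none beyond the scatter.

For compound 3 in this assay the expected value is 18000 nM, with a range from 7000 nM to 45000 nM. The step from compound 2 to compound 3 is estimated at a 1.5-fold higher number from compound 2 to compound 3 (0.17 log units; within the scatter).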

Compound 3, half-maximal inhibitory concentration: 20800 nM
Estimate against measurement, compound 3: 1.2-fold (0.06 log units) below; measured number inside the range.
By their numbers in this assay, from the lowest: compounds 2, 3 and 1 (each within the scatter of the next, the first and the last beyond it).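

Compound 3 gives the series its first single-change readings. In this assay, cyclopentyl in place of ethyl on the amide-type nitrogen, with thiophen-2-yl held constant, gives a 1.7-fold higher number from compound 2 to compound 3 (0.24 log units; within the scatter), and thiophen-2-yl in place of phenyl on the aromatic carbon, with cyclopentyl held constant, gives a 1.6-fold lower number from compound 1 to compound 3 (0.19 log units; within the scatter); neither change alone is resolved from the scatter, although compound 1 and compound 2, which differ in both places, stand apart beyond it. The data offer no measured basis for explaining either step.

On these data alone, whether a group such as benzyl or a longer chain on the amide-type nitrogen, or a pyridine ring on the aromatic carbon, would give a step beyond the scatter remains open. The amino and trifluoromethyl groups are common to all the compounds shown, so their contribution also remains unknown.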